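The compounds below may be only part of what the source reports. "The series", "measured", "known", "first", "only" and "open" are said of these compounds alone.

Compound 1 `O=C(/C(=C\c1c(-c2ccccc2)[nH]c2ccccc12)C(=O)C(F)(F)F)c1ccco1`: 8100 nM
Compound 2 `N#C/C(=C\c1c(-c2ccccc2)[nH]c2ccccc12)C(=O)c1cccs1`: 45000 nM
Compound 3 `COc1ccc(-c2[nH]c3ccc(OC)cc3c2/C=C(\C#N)S(=O)(=O)c2ccccc2)cc1`: > 100000 nM

In an ADME assay on CRL-7065 cells (Homo sapiens) for cytotoxicity, read by MTT assay, with a stated time of 96 h (on this read-out higher numbers stand for an effect only at larger amounts of compound and lower numbers for an effect already at smaller amounts), compound 1 gives 8100 nM and compound 2 gives 45000 nM. Of these two numbers compound 2 stands higher and compound 1 lower, and the gap between them is beyond the usual scatter. Compound 3 gives in this assay no number but a limit, > 100000 nM, which is the limit of > 100000 nM in this assay, at which 1 of the 3 values shown sits.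

Compound 4 `N#C/C(=C\c1c(-c2ccccc2)[nH]c2ccccc12)C(=O)c1ccc(Cl)cc1` has not yet been measured in this assay. It differs from compound 2 in one place: 4-chlorophenyl in place of thiophen-2-yl on a carbonyl carbon

No measured pair among the compounds shown carries this change, so the step is expected to be small and within the scatter, with no clear direction: a 1.1-fold lower number from compound 2 to compound 4 (0.05 log units; within the scatter). Compound 4 is therefore estimated at 40000 nM, expected to fall between 15000 nM and 100000 nM.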

Compound 4, half-maximal effective concentration: 7400 nM
Compound 4: the middle estimate sits 5.4-fold (0.73 log units) above what was measured; measured number outside the range, below it.
By their numbers in this assay, from the lowest: compounds 4 and 1 (each within the scatter of the next); then compound 2. At a limit, above all of these: compound 3.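

In this assay the group on this carbonyl carbon proves able to shift the number: 4-chlorophenyl in place of thiophen-2-yl gives a 6.1-fold lower number from compound 2 to compound 4 (0.78 log units; beyond the scatter). This is the first single-place step shown here, and exchanging one aromatic ring for another at this position is not neutral in this assay. Nothing measured among these compounds accounts for the step.

The compounds shown leave open whether the chlorine or the six-membered ring carries the change. Going by these compounds, how a plain phenyl or an amine such as morpholine would read on this carbonyl carbon also remains open.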